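A few compounds are considered here, and "the series" means these few. Any claim that something is new, unique, unknown or untested is made for them only; others in the source may bear on it.

Compound 1 `COC(=O)C1(CCCCCCCCCCc2ccccc2)CO1` is measured in a functional assay on the whole organism with Rattus norvegicus as the target, in the glucose tolerance test (on this read-out lower numbers stand for an effect already at smaller amounts and higher numbers for an effect only at larger amounts of compound), where compound 1 gives 10 mg/kg. Compound 2 `CCCCCCC1(C(=O)OC)CO1` sits level with it, as in this assay compound 2 gives 10 mg/kg, and these two share the highest number of the three measured. Compound 3 `CCCCCCCCCCCCCCC1(C(=O)OC)CO1` is furthest from compound 1, as in this assay compound 3 gives 4 mg/kg. Among the measured compounds shown here, the one step that bears on the question is a 2.5-fold lower number from compound 1 to compound 3 (0.40 log units; beyond the scatter).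

Compound 4 `CCCCCCCCCCCCCCCCCCC1(C(=O)OC)CO1` differs from compound 1 by octyl in place of phenyl on a saturated chain carbon, ten or more bonds along the chain from a saturated ring carbon. Octyl is a longer saturated chain than the butyl of compound 3, and the only relevant step goes toward a lower number. Compound 4 is therefore expected to show a 2.5-fold lower number from compound 1 to compound 4 (0.40 log units; beyond the scatter), a modest step in the same direction as that seen with compound 3, which gave 4 mg/kg. For compound 4 the estimated result is 4 mg/kg, with a range from 1.5 mg/kg to 10 mg/kg.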

Compound 4, minimum effective dose: 10 mg/kg
Beside the measured number, compound 4's estimate is 2.5-fold (0.40 log units) below it, and the stated range covers the measured number.
By their numbers in this assay, from the lowest: compound 3; then compounds 1, 2 and 4 (each within the scatter of the next).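

In this assay, the saturated chain at this place does not behave as one simple replacement for phenyl: butyl had given a lower number, but octyl in place of phenyl gives no change at the digits printed from compound 1 to compound 4 (within the scatter) and so does not carry that shift over. Extending the chain of compound 3 by butyl in place of hydrogen gives a 2.5-fold higher number from compound 3 to compound 4 (0.40 log units; beyond the scatter) and thereby reverses the earlier gain, so among compounds 1, 3 and 4 the lower number belongs only to compound 3. Nothing available accounts for this reversal.

The compounds shown leave open how chains of intermediate length, such as hexyl or heptyl, or a longer chain would read at this place. They also leave open what an amine or a carboxylic acid would do in place of phenyl.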